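A few compounds are considered here, and "the series" means these few. Any claim that something is new, unique, unknown or untested is made for them only; others in the source may bear on it.

In a functional assay on HCT-116 cells (Homo sapiens) for inhibition, read by CCK-8 assay, with a stated time of 48 h (a lower number here means a stronger inhibitor, a higher number a weaker inhibitor), compound 1 `COc1cc(-c2ccnc3cc(-c4c[nH]c5ccccc45)nn23)cc(OC)c1OC` gives 35 nM and compound 2 `COc1cc(-c2ccnc3cc(-c4ccc(C(F)(F)F)cc4)nn23)cc(OC)c1OC` gives 1860 nM as the higher of the two numbers, which makes compound 2 the weaker inhibitor. Among the measured compounds shown here, the only measured step, with 4-(trifluoromethyl)phenyl in place of 1H-indol-3-yl, is large: a 53-fold higher number from compound 1 to compound 2 (1.73 log units; beyond the scatter) here. Compound 3 `COc1cc(-c2ccnc3cc(-c4ccc5cnn(C)c5c4)nn23)cc(OC)c1OC` changes that same group again (1-methyl-1H-indazol-6-yl in place of 4-(trifluoromethyl)phenyl on an aromatic carbon) and carries 1-methyl-1H-indazol-6-yl in place of 4-(trifluoromethyl)phenyl. Like the group of compound 1 at 35 nM this one has a five-membered aromatic ring along with a six-membered one, but it is a different group, so only part of that step is expected to return. The expected change is a 6.2-fold lower number from compound 2 to compound 3 (0.79 log units; beyond the scatter) toward stronger inhibition. Compound 3 is estimated at 300 nM with 60 nM to 1500 nM as its expected range.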

Compound 3, half-maximal inhibitory concentration: 2440 nM
The estimate for compound 3 lay 8.1-fold (0.91 log units) below the measured number, outside the stated range (above it).
By their numbers in this assay, from the lowest: compound 1; then compounds 2 and 3 (each within the scatter of the next).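

In this assay, 1-methyl-1H-indazol-6-yl in place of 4-(trifluoromethyl)phenyl gives a 1.3-fold higher number from compound 2 to compound 3 (0.12 log units; within the scatter) and so recovers none of the strength of compound 1. Having a five-membered aromatic ring along with a six-membered one is therefore not enough at this position, as 1H-indol-3-yl against 1-methyl-1H-indazol-6-yl shows a 70-fold higher number from compound 1 to compound 3 (1.84 log units; beyond the scatter) here. No measurement available gives a reason for this gap. Going by these compounds, these two groups differ in several ways at once, so it stays open which difference matters. 1-Methyl-1H-indol-3-yl, or a plain amine, at this place would help to separate them.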